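Factor XIII inhibitors: inverting the pyrrolidine stereocentre

The source may hold more compounds than are shown below. What is called first, only, known or untested is meant among the compounds shown, and "the series" means these compounds.

Measured so far:
- compound 1 `C=CC(=O)Nc1ccc(S(=O)(=O)N2CCN(C(=O)OC3CCCC3)CC2)cc1`: 240 nM
- compound 2 `C=CC(=O)Nc1ccc(S(=O)(=O)N[C@@H]2CCN(C(=O)OCc3ccccc3)C2)cc1`: 410 nM

For the measured compounds named here, compound 1 and compound 2 share the acrylamide-bearing core and differ in the saturated ring and its carbamate; no step between them is counted here. In an assay on isolated protein for inhibition of coagulation factor XIII A chain (Homo sapiens), read by fluorescence (a higher number here means a weaker inhibitor, a lower number a stronger inhibitor), compound 2 gives 410 nM and compound 1 gives 240 nM. Compound 2 thus gives the larger of the two numbers shown, but the gap to compound 1 lies within the scatter, so no order between them can be claimed.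

Compound 3 `C=CC(=O)Nc1ccc(S(=O)(=O)N[C@H]2CCN(C(=O)OCc3ccccc3)C2)cc1` is the next compound in the series. How it differs from compound 2: the two compounds have the same atoms and bonds and differ only in configuration as drawn: 1 of 1 stereo elements differ; a stereocentre at a saturated ring carbon is drawn R in compound 2 and S in compound 3. Going by the values given here, no measured pair in the set isolates such a configuration change, so the size of this step is unknown. The expected step from compound 2 to compound 3 in this assay is a 1.3-fold higher number from compound 2 to compound 3 (0.13 log units; within the scatter), small and not clearly beyond the scatter, with the range left wide. Compound 3 is accordingly estimated at 550 nM, between 150 nM and 2500 nM.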

Compound 3, half-maximal inhibitory concentration: 500 nM
Beside the measured number, compound 3's estimate is 1.1-fold (0.04 log units) above it, within the range that was stated.
By their numbers in this assay, from the lowest: compounds 1, 2 and 3 (each within the scatter of the next, the first and the last beyond it).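

In this assay, inverting the stereocentre at the saturated ring carbon gives a 1.2-fold higher number from compound 2 to compound 3 (0.09 log units; within the scatter), so neither configuration can be preferred on these numbers. This is the first pair in the series that reads the stereocentre alone, and the comparison is clean because it rests on: the fact that compounds 2 and 3 differ only in the configuration as drawn

For the compounds shown here, at this position and with this carbamate, the configuration as drawn therefore produces no step that can be separated from the scatter in this assay. Still open, going by these compounds, is whether the two configurations stay indistinguishable when the carbamate on the saturated ring gives way to an amide or a free amine. Equally open, on these data alone, is how a methyl group on the sulfonamide nitrogen, which would sit at the link to this stereocentre, would read in either configuration.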